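A seven-membered ring on compound 3

The compounds below may be only part of what the source reports. "The series", "measured", "known", "first", "only" and "open" are said of these compounds alone.

Values in a functional assay on Jurkat cells (Homo sapiens) for inhibition, read by CCK-8 assay, with a stated time of 48 h; a higher number here means a weaker inhibitor of growth, a lower number a stronger inhibitor of growth:
compound 1 `Cc1ccccc1Nc1nc(Nc2cc(Cl)ccn2)ncc1Cl` gives 39600 nM
compound 2 `CCN1CCN(c2ccc(Nc3ncc(Cl)c(Nc4ccccc4C)n3)nc2)CC1` gives > 100000 nM as a limit of the assay, not a number
compound 3 `Cc1ccccc1Nc1nc(Nc2ccc(N3CCN(C)CC3)cc2)ncc1Cl` gives 13700 nM

Only two of these three results are numbers. Compound 3 (13700 nM) holds the lower of them, and compound 1 (39600 nM) stands higher by a gap beyond the scatter. Compound 2 sits at the limit of the assay, so it gives no number to compare.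

The next compound to read is compound 4 `Cc1ccccc1Nc1nc(Nc2ccc(N3CCCN(C)CC3)cc2)ncc1Cl`, which has 4-methyl-1,4-diazepan-1-yl in place of 4-methylpiperazin-1-yl on an aromatic carbon, para to a large group (4-methyl-1,4-diazepan-1-yl in place of 4-methylpiperazin-1-yl on an aromatic carbon). Everything else in compound 3 stays the same.

For the measured compounds named here, the series offers no measured pair differing in one place, so no precedent sets the size of this step. The swap keeps the methyl-capped ring with its two nitrogens and enlarges it from six-membered to seven-membered. No step beyond the scatter is therefore expected in this assay, and the value of compound 3 (13700 nM) serves as the anchor. The estimated change is small, as the expected step of a 1.1-fold higher number from compound 3 to compound 4 (0.04 log units; within the scatter) shows. For compound 4 the expected value is 15000 nM, with an estimated range of 6000 nM to 40000 nM.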

Compound 4, concentration for 50% growth inhibition: 11300 nM
For compound 4 the middle estimate is 1.3-fold (0.12 log units) above the measured one; the range from low to high includes it.
By their numbers in this assay, from the lowest: compounds 4 and 3 (each within the scatter of the next); then compound 1. At a limit, above all of these: compound 2.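

In this assay, for the compounds shown here, the step of a 1.2-fold lower number from compound 3 to compound 4 (0.08 log units; within the scatter) is the first single-place change that can be read, and it shows that the aromatic carbon para to a large group accepts 4-methyl-1,4-diazepan-1-yl in place of 4-methylpiperazin-1-yl with no change that stands out from the scatter. At this position, then, enlarging the methyl-capped ring from six-membered to seven-membered does not separate the two compounds, and neither can be ranked over the other. Going by these compounds alone, nothing measured so far bears on why the ring size leaves the number where it is.

Going by these compounds, it remains open whether this position responds to any group other than a methyl-capped ring with two nitrogens; a morpholine ring or an open-chain dimethylamino group at the same place would test that. On these data alone, the cap itself is also open: a hydrogen, an acetyl group or a longer chain in place of the methyl would show whether the capped nitrogen matters at all in this assay for either ring size.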